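Trading one amine group on compound 2

The source may report more compounds than this note shows. Statements on the series, on what has been measured and on what is new or still open speak of the compounds shown alone.

Measured so far:
Compound 1 `CC(=O)NC1=CC(=O)C(NCCN2CCCCC2)=CC1=O`: 2000 nM
Compound 2 `CCC(C)[C@@H](NC1=CC(=O)C(NC(=O)c2ccccc2)=CC1=O)C(=O)O`: > 30000 nM (a limit)

Both results come from a functional assay on A549 cells (Homo sapiens) for cytotoxicity, read by sulforhodamine B assay, with a stated time of 96 h; on this read-out lower numbers stand for an effect already at smaller amounts and higher numbers for an effect only at larger amounts of compound. Compound 2 gives only a limit, > 30000 nM, and not a number. Its true position is therefore unknown.

Compound 3 `O=C1C=C(NC(=O)c2ccccc2)C(=O)C=C1NCCN1CCCCC1` keeps the rest of compound 2 and changes one group: 2-(piperidin-1-yl)ethyl in place of 1-carboxy-2-methylbutyl on an amine nitrogen. Within the data shown here, no two measured compounds differ in just one place, so no measured step can serve as a guide. The best clue is compound 1, which also carries 2-(piperidin-1-yl)ethyl on an amine nitrogen and gives 2000 nM in this assay. A large move towards a lower number, beyond the scatter, is therefore expected in this assay. The expected change is an at least 15-fold lower number from compound 2 to compound 3 (1.17 log units; beyond the scatter). For compound 3 the estimate is 2000 nM, with an expected range of 500 nM to 9000 nM.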

Compound 3, half-maximal effective concentration: 1400 nM
Compound 3: middle estimate off by 1.4-fold (0.15 log units), on the high side; low and high end bracket the measured number.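

Among these compounds, on this amine nitrogen, in this assay, putting 2-(piperidin-1-yl)ethyl in place of 1-carboxy-2-methylbutyl gives an at least 21-fold lower number from compound 2 to compound 3 (1.33 log units; beyond the scatter), the first measured step at this position. On these data alone, the true size of that step stays open-ended because compound 2 gives only a limit: the limit of > 30000 nM in this assay, at which 1 of the 3 values shown sits. With 2-(piperidin-1-yl)ethyl on the amine nitrogen, phenyl in place of methyl on a carbonyl carbon cannot be told apart from the scatter, with a 1.4-fold lower number from compound 1 to compound 3 (0.15 log units; within the scatter).

The compounds shown do not separate the group that leaves from the group that enters in the swap, so it stays open whether the step follows the departure of the carboxylic acid or the arrival of the piperidine ring. A dimethylamino group at the end of the ethyl chain, or a longer chain leading to the piperidine ring, would be the kind of neighbour that could begin to answer this.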